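An Amide Variant of Compound 1 in Paw Edema

The compounds below may be only part of what the source reports. "The series", "measured", "known", "first", "only" and "open" are said of these compounds alone.

Compound 1, `COc1cc2c(cc1OC)C(CC(=O)O)CC2`: 26.7%
Compound 2, `COc1cc2c(cc1OC)C(CC(=O)Nc1ccccc1)CC2`: 30%

In a functional assay on the whole organism (strain Wistar) for inhibition, with Rattus norvegicus as the target, read by paw edema, with a stated time of 24 h, at a dose of 100 mg/kg (on this read-out higher numbers stand for more inhibition at the one dose given (going by the name of the read-out) and lower numbers for less inhibition), compound 1 gives 26.7%, and its nearest neighbour among the measured compounds is compound 2, the step of a number 3.3 percentage points higher from compound 1 to compound 2 (within the scatter) lying within the scatter; the two numbers cannot be ranked against each other. The unmeasured compound 3, `COc1cc2c(cc1OC)C(CC(=O)Nc1cccnc1)CC2`, differs from compound 1 in one place: (pyridin-3-yl)amino in place of hydroxy on a carbonyl carbon. Among the measured compounds shown here, the only measured step that bears on this change is the one in which anilino replaces hydroxy on the same carbonyl carbon, a number 3.3 percentage points higher from compound 1 to compound 2 (within the scatter), which produced no movement beyond the scatter. Since (pyridin-3-yl)amino, like anilino, enters as an aromatic amide in place of hydroxy, compound 3 is expected to show a step of about a number 3.3 percentage points higher from compound 1 to compound 3 (within the scatter), that is, nothing beyond the scatter. The expected value for compound 3 in this assay is therefore 30%, with a range from 17% to 43%.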

Compound 3, a percentage reported as inhibition, in the whole organism at one dose (the size of the read-out at that dose, not a potency): 36.7%
Compound 3: middle estimate off by 6.7 percentage points, on the low side; the range from low to high includes it.
By their numbers in this assay, from the lowest: compounds 1, 2 and 3 (each within the scatter of the next).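

In this assay, replacing hydroxy on the carbonyl carbon with (pyridin-3-yl)amino gives a step of a number 10 percentage points higher from compound 1 to compound 3 (within the scatter), so this second aromatic amide, like the anilino amide, does not separate from the acid. Among the compounds shown here, the new compound also allows the first comparison at the amide-type nitrogen, where pyridin-3-yl in place of phenyl gives a number 6.7 percentage points higher from compound 2 to compound 3 (within the scatter), so a hetero atom in that six-membered aromatic ring produces no movement that can be read. Nothing available offers an explanation for these numbers.

Still open, from the compounds shown here alone, is whether a morpholin-4-yl or benzylamino group on the carbonyl carbon, or a chlorine on the phenyl of the anilino amide, would move the number beyond the scatter. The single dose and single time also leave open whether the three compounds differ at all on this read-out.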